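Swapping a fluorophenyl for a furan on a dienone chain

This account rests on a few compounds, and the source may have more. Where it says the series, first, only, none or still open, it means among the compounds named here.

Compound 1 `CC1=C(/C=C/C(=O)/C=C/c2ccccc2)C(C)(C)CCC1`: in a functional assay on Hep cells (Homo sapiens) for cytotoxicity, read by sulforhodamine B assay, with a stated time of 48 h (a higher number here means a weaker inhibitor, a lower number a stronger inhibitor), compound 1 gives 62200 nM.
Compound 2 `CC1=C(/C=C/C(=O)/C=C/c2ccccc2Cl)C(C)(C)CCC1`: in this assay compound 2 gives 54200 nM.
Compound 3 `CC1=C(/C=C/C(=O)/C=C/c2ccccc2F)C(C)(C)CCC1`: in this assay compound 3 gives 23600 nM.

Compound 3 has the lowest number of the three; the steps of a 2.6-fold lower number from compound 1 to compound 3 (0.42 log units; beyond the scatter) and a 2.3-fold lower number from compound 2 to compound 3 (0.36 log units; beyond the scatter) both lie beyond the scatter, whereas a 1.1-fold lower number from compound 1 to compound 2 (0.06 log units; within the scatter) does not. Compound 4 `CC1=C(/C=C/C(=O)/C=C/c2ccoc2)C(C)(C)CCC1` differs from compound 3 by furan-3-yl in place of 2-fluorophenyl on a double-bonded chain carbon bound to a double-bonded chain carbon. Among the compounds with values here, none of the measured steps exchanges the whole ring; they only vary one substituent on the phenyl, and the fluoro that lowered the number in compound 3 is lost here. In this assay compound 4 is therefore expected to move back toward the numbers of compound 1 and compound 2, a step of about a 1.7-fold higher number from compound 3 to compound 4 (0.23 log units; within the scatter). The estimate for compound 4 is 40000 nM, within 15000 nM to 110000 nM.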

Compound 4, half-maximal inhibitory concentration: > 100000 nM
Compound 4 was reported as a limit; the forecaster's own chance of this, stated with the estimate: 10%; middle value at least 2.5-fold (0.39 log units) from the limit.
By their numbers in this assay, from the lowest: compound 3; then compounds 2 and 1 (each within the scatter of the next). At a limit, above all of these: compound 4.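

In this assay, exchanging the whole ring at this position matters more than the substituent changes did: furan-3-yl in place of 2-fluorophenyl gives an at least 4.2-fold higher number from compound 3 to compound 4 (0.62 log units; beyond the scatter). Against the other two rings, the floors are an at least 1.6-fold higher number from compound 1 to compound 4 (0.20 log units; that floor lies within the scatter) and an at least 1.8-fold higher number from compound 2 to compound 4 (0.26 log units; that floor lies within the scatter), so these two steps fix no order. The result for compound 4 is a limit, not a number: the limit of > 100000 nM in this assay, at which 1 of the 4 values shown sits.

From the compounds shown here alone, how far compound 4 lies beyond that limit stays unknown. Also open, going by these compounds, is whether a thiophene ring, a pyridine ring or a phenyl carrying an amine would stay near compound 3 or follow compound 4.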